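Aryl variation at the shared core: compound 3 to compound 4

The source may report more compounds than this note shows. Statements on the series, on what has been measured and on what is new or still open speak of the compounds shown alone.

Measured compounds:
- compound 1, `COc1ccc(S(=O)(=O)N2CCc3cccc(-c4cccnc4)c32)cc1`: 68.5 nM
- compound 2, `COc1ccc(S(=O)(=O)n2ccc3cccc(-c4ccc(F)cc4)c32)cc1`: 170 nM
- compound 3, `COc1ccc(S(=O)(=O)N2CCc3cccc(-c4ccc(F)c(F)c4)c32)cc1`: 55.5 nM

In a functional assay on MKN-45 cells (Homo sapiens) for inhibition, with a stated time of 72 h (on this read-out lower numbers stand for stronger inhibition and higher numbers for weaker inhibition), compound 3 gives the lowest of the three numbers. Its nearest neighbour is compound 1, whose value in this assay lies within the scatter of that of compound 3, so no order between the two can be claimed. Compound 2, which differs from compound 3 in more than one place, shows the highest of the three numbers in this assay.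

The next compound, compound 4 `COc1ccc(S(=O)(=O)N2CCc3cccc(-c4ccc(N)cc4)c32)cc1`, is not yet measured. It differs from compound 3 in one place: 4-aminophenyl in place of 3,4-difluorophenyl on an aromatic carbon.

Among the measured compounds shown here, only one measured step touches this position. a 1.2-fold lower number from compound 1 to compound 3 (0.09 log units; within the scatter). That step exchanged one aryl group for another at the same place and left the number within the scatter. Nothing measured speaks to 4-aminophenyl itself, so the expectation rests on that single step: an exchange of the aryl group at this place is expected to move the number little, with no direction beyond the scatter, which is what a 1.4-fold higher number from compound 3 to compound 4 (0.16 log units; within the scatter) expresses as an estimate.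

Compound 4 is therefore estimated at 80 nM in this assay, with an expected range from 30 nM to 250 nM.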

Compound 4, half-maximal inhibitory concentration: 162 nM
Beside the measured number, compound 4's estimate is 2.0-fold (0.31 log units) below it; low and high end bracket the measured number.
By their numbers in this assay, from the lowest: compounds 3 and 1 (each within the scatter of the next); then compounds 4 and 2 (each within the scatter of the next).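

In this assay, among the compounds shown here, the aryl group on this aromatic carbon now shows a change beyond the scatter: 4-aminophenyl in place of 3,4-difluorophenyl gives a 2.9-fold higher number from compound 3 to compound 4 (0.47 log units; beyond the scatter) and 4-aminophenyl in place of pyridin-3-yl gives a 2.4-fold higher number from compound 1 to compound 4 (0.37 log units; beyond the scatter), whereas the only earlier step here, a 1.2-fold lower number from compound 1 to compound 3 (0.09 log units; within the scatter), stayed within it. For the compounds shown here, the position is therefore not indifferent to every aryl exchange, although both new steps are modest and the claim covers only compounds 1, 3 and 4, with 4-aminophenyl the one group of the three that stands apart from the other two. Nothing at hand bears on what lies behind these steps.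

Each new step changes the whole aryl group at once, so the compounds shown do not separate the entry of the amino group from the loss of the two fluorines in compound 3 or of the ring nitrogen in compound 1. An unsubstituted phenyl, a 3-aminophenyl or a 4-hydroxyphenyl on the same core would help to settle whether the amine itself, its place on the ring or some other feature of the group goes with the higher number.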